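The source may report more compounds than this note shows. Statements on the series, on what has been measured and on what is new or still open speak of the compounds shown alone.

In a functional assay on A2780 cells (Homo sapiens) for antiproliferative activity, read by MTT assay, with a stated time of 48 h (on this read-out higher numbers stand for weaker inhibition of growth and lower numbers for stronger inhibition of growth), compound 1 `COC(=O)N1N=C(c2ccccc2)CC1c1ccc(OC)cc1` reads > 10000 nM, which is a limit of the assay and not a number. For the measured compounds named here, compound 2 `CCOc1cccc(C2=NN(C(=O)OC)C(c3cc(OC)c(OC)c(OC)c3)C2)c1` gives 760 nM, the only actual number available so far in this assay. It therefore has no measured neighbour to be ranked against, and its value serves as the starting point for what follows.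

The next compound, compound 3 `COC(=O)N1N=C(c2ccc(OC)c(OC)c2)CC1c1cc(OC)c(OC)c(OC)c1`, has not yet been measured. It differs from compound 2 in one place: 3,4-dimethoxyphenyl in place of 3-ethoxyphenyl on a carbon with a double bond to nitrogen. In words, 3,4-dimethoxyphenyl stands in place of 3-ethoxyphenyl on a carbon with a double bond to nitrogen, while the rest of the structure stays the same.

Going by the values given here, no measured pair in this small set shows what a single change of this kind does, so the expectation has little to rest on. In this assay, no shift beyond the usual scatter is expected, although a wide margin must be allowed in either direction. The expected change, a 1.1-fold higher number from compound 2 to compound 3 (0.02 log units; within the scatter), is therefore small. For compound 3 the estimated value is 800 nM, with an expected range of 200 nM to 4000 nM.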

Compound 3, concentration for 50% growth inhibition: 11400 nM
Compound 3: the middle estimate sits 14-fold (1.15 log units) below what was measured, and the stated range ends below it.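

Changing the aryl group on the carbon with a double bond to nitrogen is far from a neutral edit in this assay: replacing 3-ethoxyphenyl with 3,4-dimethoxyphenyl gives a 15-fold higher number from compound 2 to compound 3 (1.18 log units; beyond the scatter). Both groups hold one six-membered aromatic ring of carbon only, yet growth inhibition becomes much weaker, so at this place the groups on that ring matter and not only the presence of the ring. Compound 1 reads only as a limit and not as a number, which shows that compounds this weak sit close to where the assay stops giving numbers: the limit of > 10000 nM in this assay, at which 1 of the 3 values shown sits.

This single pair cannot separate the effect of removing the ethoxy group from that of having two methoxy groups on the ring; the compounds shown do not say which of the two matters more. They also leave open how 3-methoxyphenyl, a ring carrying a hydroxyl group or an amine, or a chain longer than ethoxy would read at this place in this assay.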